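Ethyl on the shared core: compound 3 to compound 4

The source may hold more compounds than are shown below. What is called first, only, known or untested is meant among the compounds shown, and "the series" means these compounds.

Values in a functional assay on A549 cells (Homo sapiens) for cytotoxicity; on this read-out higher numbers stand for an effect only at larger amounts of compound and lower numbers for an effect already at smaller amounts:
- compound 1 `COC1=C(C)C(=O)/C(=C(O)/C=C/c2ccc(Br)cc2)C(=O)C1(C)C`: 1.4 ug/mL
- compound 2 `COC1=C(C)C(=O)/C(=C(O)/C=C/c2c(C)cc(C)cc2C)C(=O)C1(C)C`: 8 ug/mL
- compound 3 `COC1=CC(O)=C(C(=O)/C=C/c2ccccc2)C(=O)C1(C)C`: > 5 ug/mL (a limit)

Compound 3 stands at > 5 ug/mL in this assay, and this is a limit of the assay and not a number. It therefore gives no exact starting point for the next comparison.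

Compound 4 `CCC1=C(OC)C(C)(C)C(=O)C(C(=O)/C=C/c2ccccc2)=C1O` is the next to be read in this assay. The change from compound 3 is ethyl in place of hydrogen on a double-bonded ring carbon. Going by the values given here, no two measured compounds differ in one place only, so no measured step sizes this change.

Among the compounds with values here, the only numbers available are those of compound 1 at 1.4 ug/mL and compound 2 at 8 ug/mL, and they serve only as a rough guide to the span of the range. No step beyond the scatter is expected in this assay, and neither direction is favoured, so the estimated change is a step that the limit leaves unreadable from compound 3 to compound 4. A further limit reading would not be a surprise. For compound 4 the estimated value is 6 ug/mL, with an expected range from 2 ug/mL to 20 ug/mL.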

Compound 4, concentration for half-maximal effect: 5.5 ug/mL
Estimate against measurement, compound 4: 1.1-fold (0.04 log units) above; low and high end bracket the measured number.
By their numbers in this assay, from the lowest: compound 1; then compounds 4 and 2 (each within the scatter of the next).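

Compound 3 is recorded only as a limit, > 5 ug/mL. Compound 4 therefore gives no readable step from compound 3, because the comparison rests on a limit: the limit of > 5 ug/mL in this assay, at which 1 of the 4 values shown sits.

The compounds shown leave open the size and direction of the change from hydrogen to ethyl on a double-bonded ring carbon.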